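A few compounds are considered here, and "the series" means these few. Any claim that something is new, unique, unknown or untested is made for them only; others in the source may bear on it.

Three compounds share one core and were tested in the same way. Compound 1 `O=C(/C=C/c1ccc(OCc2cn(Cc3ccc(F)cc3)nn2)cc1)c1ccc(Br)cc1` gives 37% in a functional assay on MCF7 cells (Homo sapiens) for inhibition, read by MTT assay, with a stated time of 48 h, tested at 10 uM; a lower number here means less inhibition of growth, a higher number more inhibition of growth at the concentration tested. Compound 2 `COc1ccc(C(=O)/C=C/c2ccc(OCc3cn(Cc4cccc(Br)c4)nn3)cc2)cc1` gives 45%, and compound 3 `COc1ccc(C(=O)/C=C/c2ccc(OCc3cn(Cc4ccc(Br)cc4)nn3)cc2)cc1` gives 53%, the highest of the three numbers. Going by the values given here, the only single change measured so far, a number 8 percentage points higher from compound 2 to compound 3 (within the scatter), lies within the scatter. Compound 4 `COc1ccc(C(=O)/C=C/c2ccc(OCc3cn(Cc4ccc(F)cc4)nn3)cc2)cc1` has not yet been measured; it differs from compound 3 by fluoro in place of bromo on an aromatic carbon. Among the compounds with values here, no measured step covers this exchange of halogens. Compound 1 also carries the fluoro group but differs from compound 3 in a second place as well; compound 1 gives 37%, which only hints that the number may drop. Compound 4 is therefore expected to show a number 9 percentage points lower from compound 3 to compound 4 (within the scatter). The estimate for compound 4 is 44%, between 28% and 58%.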

Compound 4, percent growth inhibition at one concentration: 15%
Beside the measured number, compound 4's estimate is 29 percentage points above it; the measured number lies below the stated range.
By their numbers in this assay, from the lowest: compound 4; then compounds 1, 2 and 3 (each within the scatter of the next, the first and the last beyond it).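

In this assay, going by these compounds alone, the halogen on this aromatic carbon matters far more than the earlier compounds suggested: fluoro in place of bromo gives a number 38 percentage points lower from compound 3 to compound 4 (beyond the scatter) and is a large step. Set against the 3-bromophenyl compound, the 4-fluorophenyl group gives a number 30 percentage points lower from compound 2 to compound 4 (beyond the scatter) as well. With fluoro kept, methoxy in place of bromo on another aromatic carbon gives a number 22 percentage points lower from compound 1 to compound 4 (beyond the scatter) and so shows that this second place also counts. Nothing measured here explains these drops.

Going by these compounds, whether a chloro or a methyl group on this carbon would stay near compound 3 or fall toward compound 4 remains open.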